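Hydroxy for amino on the pyrrolidine: solubility expectation

The source may report more compounds than this note shows. Statements on the series, on what has been measured and on what is new or still open speak of the compounds shown alone.

Measured compounds in a physicochemical assay for solubility, read by HPLC, using the shake flask method, in phosphate buffer, with a stated time of 2 h, at pH 6.5; on this read-out lower numbers stand for lower solubility and higher numbers for higher solubility:
- compound 1, `Nc1ncc(-c2ccc(C(=O)N3CCC(N)C3)cc2)nc1-c1ccc(C(F)(F)F)cc1`: 102000 nM
- compound 2, `Nc1ncc(-c2ccc(C(=O)N3CC[C@H](O)C3)cc2)nc1-c1ccc(C(F)(F)F)cc1`: 68000 nM
- compound 3, `Nc1ncc(-c2ccc(C(=O)N3CCC(O)C3)cc2)nc1-c1ccc(C(F)(F)F)cc1`: 77000 nM

Compound 1 gives the highest of the three numbers in this assay, but neither of its neighbours is far away: the step of a 1.5-fold lower number from compound 1 to compound 2 (0.18 log units; within the scatter) and the step of a 1.3-fold lower number from compound 1 to compound 3 (0.12 log units; within the scatter) both sit inside the usual scatter, so the three compounds are best read as a single cluster.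

Compound 4, `Nc1ncc(-c2ccc(C(=O)N3CC[C@@H](O)C3)cc2)nc1-c1ccc(C(F)(F)F)cc1`, has not yet been measured. It differs from compound 1 by 3-hydroxypyrrolidin-1-yl in place of 3-aminopyrrolidin-1-yl on a carbonyl carbon. The same exchange is already covered by the two measured steps above, and the step of a 1.1-fold higher number from compound 2 to compound 3 (0.05 log units; within the scatter), which rests on (the fact that one of compounds 2 and 3 is drawn with a defined configuration and the other without, at the place where they differ), shows that drawing or omitting the configuration at that ring carbon made no difference beyond the scatter.

Compound 4 is therefore expected to fall in with compounds 2 and 3, with a step of a 1.5-fold lower number from compound 1 to compound 4 (0.16 log units; within the scatter) that stays within the scatter. The estimate for compound 4 in this assay is 70000 nM, with a range from 40000 nM to 120000 nM.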

Compound 4, solubility: 90000 nM
Estimate against measurement, compound 4: 1.3-fold (0.11 log units) below, within the range that was stated.
By their numbers in this assay, from the lowest: compounds 2, 3, 4 and 1 (each within the scatter of the next).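

With both drawn configurations of the 3-hydroxypyrrolidin-1-yl group now available, the configuration at its ring carbon can be compared directly, and in this assay the step of a 1.3-fold higher number from compound 2 to compound 4 (0.12 log units; within the scatter) shows no separation beyond the scatter, in a comparison that isolates this one feature: the fact that compounds 2 and 4 differ only in the configuration as drawn. The step of a 1.2-fold higher number from compound 3 to compound 4 (0.07 log units; within the scatter) likewise leaves the R form inseparable from the form drawn without a configuration: the fact that one of compounds 3 and 4 is drawn with a defined configuration and the other without, at the place where they differ. The step of a 1.1-fold lower number from compound 1 to compound 4 (0.05 log units; within the scatter) extends the earlier reading of the exchange to the R form, so neither the exchange nor the configuration separates these compounds at this position.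

The compounds shown leave open how the read-out would respond to a carboxylic acid or an open-chain amine in place of the ring on the carbonyl carbon. Going by these compounds, whether configuration matters for the 3-aminopyrrolidin-1-yl group also remains open, since compound 1 carries no drawn configuration.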